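A few compounds are considered here, and "the series" means these few. Any claim that something is new, unique, unknown or untested is made for them only; others in the source may bear on it.

Measured in an ADME assay on liver (Rattus norvegicus) for metabolic stability, using microsomes; on this read-out lower numbers stand for a shorter-lived compound and higher numbers for a longer-lived compound:
Compound 1 `CN1Cc2cc(ccc2S(=O)(=O)C2CC2)NC(=O)CCc2cc(ccc2OCC2CC2)[C@@H](Nc2ccc3c(N)ncc(F)c3c2)C1=O`: 0.383 h
Compound 2 `CN1CCc2cccc(c2)[C@@H](Nc2ccc3c(N)ncc(F)c3c2)C(=O)N(C)Cc2cc(ccc2S(=O)(=O)C2CC2)NC1=O`: 0.1 h

Of these two, compound 1 holds the higher number at 0.383 h, and compound 2 gives 0.1 h, a gap beyond the usual scatter. Compound 3 `COc1ccc2cc1CCC(=O)Nc1ccc(S(=O)(=O)C3CC3)c(c1)CN(C)C(=O)[C@@H]2Nc1ccc2c(N)ncc(F)c2c1` has not yet been measured in this assay. It departs from compound 1 in one place: hydrogen in place of cyclopropyl on a saturated chain carbon bound to an oxygen on an aromatic ring. In words, this is hydrogen in place of cyclopropyl on a saturated chain carbon bound to an oxygen on an aromatic ring, so cyclopropylmethoxy becomes methoxy. Among the measured compounds shown here, no measured pair of compounds shows this change or any other single change, so the size of the step remains a judgement. Little movement is expected, perhaps a slight rise, and nothing beyond the scatter. The estimated move is a 1.2-fold higher number from compound 1 to compound 3 (0.07 log units; within the scatter). For compound 3 the expected half-life is 0.45 h, with an estimated range of 0.2 h to 0.9 h.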

Compound 3, half-life: 0.267 h
Estimate against measurement, compound 3: 1.7-fold (0.23 log units) above; low and high end bracket the measured number.
By their numbers in this assay, from the lowest: compound 2; then compounds 3 and 1 (each within the scatter of the next).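

Among the compounds shown here, replacing cyclopropylmethoxy with methoxy gives the first single-change reading at this position: in this assay the step is a 1.4-fold lower number from compound 1 to compound 3 (0.16 log units; within the scatter). The cyclopropyl on a saturated chain carbon bound to an oxygen on an aromatic ring can therefore be removed without a shift beyond the scatter, and the half-lives of compound 1 and compound 3 cannot be told apart. No measurement shown accounts for this outcome.

For the compounds shown here, with only this one change read at the position, it remains open whether the half-life would stay within the scatter with other groups there, such as a longer chain, an amine or a carboxylic acid on that chain carbon. On these data alone, it is also open whether a hydroxyl in place of the whole ether would behave as methoxy does.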